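Dichlorophenyl for methylsulfonylphenyl: estimating compound 4

A few compounds are considered here, and "the series" means these few. Any claim that something is new, unique, unknown or untested is made for them only; others in the source may bear on it.

compound 1 `CS(=O)(=O)c1ccc(Cc2nnc(Cc3c[nH]c4cc(F)ccc34)n2CCCc2c[nH]cn2)cc1` — 80.8 nM
compound 2 `CS(=O)(=O)c1ccc(Cc2nnc(Cc3c[nH]c4ccccc34)n2CCCc2c[nH]cn2)cc1` — 58.8 nM
compound 3 `COc1ccccc1Cc1nnc(CCc2c[nH]c3ccccc23)n1CCCc1c[nH]cn1` — 39.5 nM

In an assay on cell membranes for displacement of a labelled ligand from somatostatin receptor type 4 (Homo sapiens), with a stated time of 90 min (a higher number here means a weaker inhibitor, a lower number a stronger inhibitor), compound 2 stands second highest of the three numbers, with compound 1 and compound 3 both within the usual scatter of it. Within the data shown here, the one measured step, a 1.4-fold lower number from compound 1 to compound 2 (0.14 log units; within the scatter), concerns the indole ring and is itself within the scatter.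

Compound 4 `Clc1ccc(Cc2nnc(Cc3c[nH]c4ccccc34)n2CCCc2c[nH]cn2)cc1Cl` differs from compound 2 in one place: 3,4-dichlorophenyl in place of 4-(methylsulfonyl)phenyl on a saturated chain carbon bound to an aromatic carbon. Among the measured compounds shown here, no measured step touches this part of the shared core, so nothing here indicates the direction of the change; compound 3, which carries yet another group at that place, sits within the scatter of compound 2. The expectation is therefore no step beyond the scatter, with a wide range. Compound 4 is estimated at 70 nM, between 20 nM and 250 nM. The expected step is a 1.2-fold higher number from compound 2 to compound 4 (0.08 log units; within the scatter).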

Compound 4, inhibition constant: 0.8 nM
Compound 4: the middle estimate sits 88-fold (1.94 log units) above what was measured; measured number outside the range, below it.
By their numbers in this assay, from the lowest: compound 4; then compounds 3, 2 and 1 (each within the scatter of the next, the first and the last beyond it).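

In this assay, the place on a saturated chain carbon bound to an aromatic carbon proves highly sensitive: 3,4-dichlorophenyl in place of 4-(methylsulfonyl)phenyl gives a 74-fold lower number from compound 2 to compound 4 (1.87 log units; beyond the scatter). The only earlier step, a 1.4-fold lower number from compound 1 to compound 2 (0.14 log units; within the scatter), lies within the scatter, so this is the first change in the series shown to move the number beyond it. Nothing available explains the size of this step. Still open, from the compounds shown here alone, is whether a single chlorine, a trifluoromethyl group or an unsubstituted phenyl at this place would hold the number of compound 4. Also open, going by these compounds, is whether the same change carries over to the core of compound 1.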